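One Sulfonyl Substituent Exchanged, Cell Growth Effect Awaited

The source may hold more compounds than are shown below. What is called first, only, known or untested is meant among the compounds shown, and "the series" means these compounds.

Of the compounds shown here, three have been tested in an ADME assay on BJ cells (Homo sapiens) for antiproliferative activity, with a stated time of 72 h; on this read-out higher numbers stand for an effect only at larger amounts of compound and lower numbers for an effect already at smaller amounts. Compound 1 `COC(=O)c1cc(=O)c2c(OC)cc(OC)cc2[nH]1` gives only a limit in this assay, > 34400 nM. Compound 2 `COC(=O)c1cc(=O)c2cc(N)ccc2[nH]1` also gives only a limit, > 67200 nM. Compound 3 `COc1ccc(-c2cc(=O)c3c(OC)cc(OC)cc3n2S(=O)(=O)c2ccc(C=O)cc2)cc1` likewise reaches only a limit, > 34400 nM. Compound 3 thus stands at the limit of > 34400 nM in this assay, at which 2 of the 3 values shown sit, where compound 1 also sits, while compound 2 sits at the limit of > 67200 nM in this assay, at which 1 of the 3 values shown sits; none of the three shows a measurable effect on cell growth within the tested range.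

Compound 4 `COc1ccc(-c2cc(=O)c3c(OC)cc(OC)cc3n2S(=O)(=O)c2ccc(Br)s2)cc1` has not yet been measured. It differs from compound 3 in one place: 5-bromothiophen-2-yl in place of 4-formylphenyl on a sulfonyl sulfur. Among the compounds with values here, no measured pair of compounds shares this kind of change, so there is no earlier step to lean on. The step from compound 3 to compound 4 is expected to be small, probably none beyond the scatter, and is estimated as a number no higher from compound 3 to compound 4 (the limit leaves the size open). This expectation rests on compound 3 alone, which shows only the limit > 34400 nM. Compound 4 is therefore expected to give about 34400 nM in this assay, within a range from 8000 nM to 100000 nM, and most likely again only a limit.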

Compound 4, half-maximal effective concentration: > 48200 nM
Compound 4: a limit, no number (the forecaster's own chance of this, stated with the estimate: 70%); middle value at least 1.4-fold (0.14 log units) from the limit.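

Compound 3 and compound 4 each give only a limit, and the step between them cannot be read. The compounds shown leave open whether 5-bromothiophen-2-yl in place of 4-formylphenyl on a sulfonyl sulfur alters cell growth, and what amount of either compound would produce an effect.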